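This account rests on a few compounds, and the source may have more. Where it says the series, first, only, none or still open, it means among the compounds named here.

In a functional assay on cells (Panel melanoma (Carcinoma cell lines), Homo sapiens) for inhibition (a lower number here means a stronger inhibitor of growth, a higher number a weaker inhibitor of growth), compound 1 (`Cc1ccc(/C=C2\CN(C)CC3=C2N=C(S)NC3c2ccc(C)cc2)cc1`) gives 58800 nM and compound 2 (`CN1C/C(=C\c2cccs2)C2=NN(C)C(c3cccs3)C2C1`) gives 85000 nM, so the two values lie within the scatter of each other. Compound 3 (`CN1C/C(=C\c2cccs2)C2=NN(c3ccccc3)C(c3cccs3)C2C1`) carries phenyl in place of methyl on an amine nitrogen in a ring. Going by the values given here, no measured step covers this change, so the expectation starts from compound 2 at 85000 nM and is tentative. A moderate move towards stronger growth inhibition is expected, with the estimated size being a 2.7-fold lower number from compound 2 to compound 3 (0.42 log units; beyond the scatter). For compound 3 the estimated value is 32000 nM, with an expected range of 10000 nM to 85000 nM.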

Compound 3, concentration for 50% growth inhibition: 42500 nM
Compound 3: the middle estimate sits 1.3-fold (0.12 log units) below what was measured; low and high end bracket the measured number.
By their numbers in this assay, from the lowest: compounds 3, 1 and 2 (each within the scatter of the next).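

Replacing methyl with phenyl on the amine nitrogen in a ring gives only a small step in this assay (a 2.0-fold lower number from compound 2 to compound 3 (0.30 log units; within the scatter)). This position therefore carries the larger aromatic ring, at 6 heavy atoms against 1, with no shift beyond the scatter, and growth inhibition stays weak in this pair. No supporting measurement bears on this result.

On these data alone, it remains open whether a benzyl group, a substituted phenyl or a longer chain bearing an amine on this nitrogen would move the number beyond the scatter. As far as these compounds go, the contribution of the thiophen-2-yl group also remains open.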